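The compounds below may be only part of what the source reports. "The series", "measured", "known", "first", "only" and "open" are said of these compounds alone.

Going by the values given here, compound 1 `Cc1cnc(-c2ccccc2C(C)C)nc1NCc1ccc(-c2cccnc2)cc1` has the lower of the two numbers so far in an assay on a protein complex for inhibition of ubiquitin carboxyl-terminal hydrolase 1/WD repeat-containing protein 48 (Homo sapiens), read by fluorescence (a lower number here means a stronger inhibitor, a higher number a weaker inhibitor), where compound 1 gives 70 nM. Among the compounds with values here, compound 2 `CC(C)c1ccccc1-c1ncc(N(C)C)c(NCc2ccc(-c3cccnc3)cc2)n1` carries a dimethylamino in place of the methyl on an aromatic carbon, and in this assay compound 2 gives 190 nM; the step of a 2.7-fold higher number from compound 1 to compound 2 (0.43 log units; beyond the scatter) is the only measured step available. Compound 3 `Cc1cnc(-c2ccccc2C2CC2)nc1NCc1ccc(-c2cccnc2)cc1` differs from compound 1 at another place: cyclopropyl in place of isopropyl on an aromatic carbon. No measured step touches this part of the shared core, and the one shown step concerns a different aromatic carbon, so it gives no direct guide to the present change. With nothing in the data pointing either way, a change within the scatter is expected for compound 3 in this assay. The estimate for compound 3 in this assay is 100 nM, with a range from 40 nM to 250 nM. For compound 3 this means an expected step of a 1.4-fold higher number from compound 1 to compound 3 (0.15 log units; within the scatter).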

Compound 3, half-maximal inhibitory concentration: 180 nM
Beside the measured number, compound 3's estimate is 1.8-fold (0.26 log units) below it, and the stated range covers the measured number.
By their numbers in this assay, from the lowest: compound 1; then compounds 3 and 2 (each within the scatter of the next).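

In this assay, the exchange of 2-isopropylphenyl for 2-cyclopropylphenyl gives a 2.6-fold higher number from compound 1 to compound 3 (0.41 log units; beyond the scatter), a modest step, but one that shows this position is not indifferent to the change. Going by these compounds alone, until now, the only measured step concerned a different aromatic carbon, so this is the first sign that the group on the aromatic carbon ortho to a large group also affects the number. Isopropyl and cyclopropyl have the same heavy-atom count, all carbon, and the computed difference is the three-membered ring, but nothing available explains why the number moves.

From the compounds shown here alone, it remains open how ethyl, tert-butyl or methoxy would fare at this place. Also open, going by these compounds, is whether the same step would appear with dimethylamino in place of the methyl, as in compound 2.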